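The source may hold more compounds than are shown below. What is called first, only, known or untested is meant among the compounds shown, and "the series" means these compounds.

Measured so far:
compound 1, `CCCCOC(=O)NS(=O)(=O)c1sc(CC(C)C)cc1-c1ccc(C(=O)c2ncco2)cc1`, 13.8 nM;
compound 2, `CCCCOC(=O)NS(=O)(=O)c1sc(CC(C)C)cc1-c1ccc(Cc2ncco2)cc1`, 3.9 nM.

Both compounds were tested in an assay on membranes from uterus for displacement of a labelled ligand from Angiotensin type II receptor (Sus scrofa), with a stated time of 1.5 h; a higher number here means a weaker inhibitor, a lower number a stronger inhibitor. Going by the values given here, the single step between them, a 3.5-fold lower number from compound 1 to compound 2 (0.55 log units; beyond the scatter), comes from a change of the linker that carries the ring on the aromatic carbon. Among the compounds with values here, on the two numbers available, compound 2 has the lower inhibition constant, and its only neighbour is compound 1, separated by that step.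

Compound 3, `CCCCOC(=O)NS(=O)(=O)c1sc(CC(C)C)cc1-c1ccc(Cc2nnc(C(F)(F)F)o2)cc1`, has not yet been measured. Compound 3 differs from compound 2 in one place: 5-(trifluoromethyl)-1,3,4-oxadiazol-2-yl in place of 1,3-oxazol-2-yl on a saturated chain carbon bound to an aromatic carbon. Within the data shown here, none of the measured steps bears on this change. The step from compound 1 to compound 2 concerns the linker, not the ring that sits on it, so it gives no guide to the size or direction of what is expected here. With nothing in the data to point either way, compound 3 is expected to sit close to compound 2, with a change of about a 1.2-fold higher number from compound 2 to compound 3 (0.06 log units; within the scatter) in this assay, not beyond the scatter. For compound 3 the estimated inhibition constant in this assay is 4.5 nM, with a likely range from 1.5 nM to 14 nM.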

Compound 3, inhibition constant: 328 nM
Compound 3: middle estimate off by 73-fold (1.86 log units), on the low side, outside the stated range (above it).
By their numbers in this assay, from the lowest: compound 2; then compound 1; then compound 3.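

In this assay the group on a saturated chain carbon bound to an aromatic carbon proves far from interchangeable: replacing 1,3-oxazol-2-yl with 5-(trifluoromethyl)-1,3,4-oxadiazol-2-yl gives an 84-fold higher number from compound 2 to compound 3 (1.92 log units; beyond the scatter), so this position responds strongly to a change of the ring and its substituent, which the linker change alone could not show. The new compound also falls behind the carbonyl-linked compound, with a 24-fold higher number from compound 1 to compound 3 (1.38 log units; beyond the scatter), so the advantage of the methylene-linked oxazole over the carbonyl-linked oxazole does not carry over to this new group. Nothing shown here gives a measured reason for the loss.

The single change swaps the ring and adds trifluoromethyl together, so the compounds shown cannot tell which part accounts for the step; the unsubstituted 1,3,4-oxadiazol-2-yl or its 5-methyl counterpart would separate the two. On these data alone, it also remains open whether other groups at this place, such as 1,3-thiazol-2-yl or a 5-(trifluoromethyl)-1,3-oxazol-2-yl, would stay nearer to compound 2 in this assay.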